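This account rests on a few compounds, and the source may have more. Where it says the series, first, only, none or still open, it means among the compounds named here.

Compound 2, with the structure `CCn1c(C(=O)NCCC(=O)O)ccc1C(CC)(CC)c1ccc(OCC(O)C(C)(C)C)c(C)c1`, is the weaker of the two compounds measured in an assay on HL-60 cells for agonist activity at vitamin D3 receptor (Homo sapiens), with a stated time of 96 h; a higher number here means that more compound is needed for the effect, a lower number that less compound is needed: compound 2 gives 33200 nM, the highest number in this set. Its nearest neighbour is compound 1, with the structure `CCn1c(C(=O)N[C@@H](C)CO)ccc1C(CC)(CC)c1ccc(OCC(O)C(C)(C)C)c(C)c1`, and compound 1 gives 1.06 nM in this assay. Among the compounds with values here, the only step recorded between them, a 31000-fold higher number from compound 1 to compound 2 (4.50 log units; beyond the scatter), shows how much the number rose when the 1-(hydroxymethyl)ethyl group on the amide-type nitrogen gave way to 2-carboxyethyl.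

Compound 3, with the structure `CCn1c(C(=O)N[C@@H](C)C(=O)O)ccc1C(CC)(CC)c1ccc(OCC(O)C(C)(C)C)c(C)c1`, differs from compound 2 by 1-carboxyethyl in place of 2-carboxyethyl on an amide-type nitrogen. The carboxylic acid is kept, but the chain is now branched in the same way as in compound 1. Within the data shown here, no measured step covers this rearrangement directly; the single step from compound 1 to compound 2 mixes two changes at once, the loss of the hydroxymethyl group and the arrival of the acid, so it offers only a loose guide. The acid stays, so compound 3 is expected to remain far from compound 1, with at most a modest move downward: the estimated step from compound 2 to compound 3 is a 2.8-fold lower number from compound 2 to compound 3 (0.44 log units; beyond the scatter). For compound 3 in this assay the expected value is 12000 nM, within a range from 1500 nM to 80000 nM.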

Compound 3, half-maximal effective concentration: 4.07 nM
Beside the measured number, compound 3's estimate is 2900-fold (3.47 log units) above it; measured number below the stated range.
By their numbers in this assay, from the lowest: compound 1; then compound 3; then compound 2.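

In this assay, the result shows that the carboxylic acid alone does not decide the outcome at this position: with the same atoms on the amide-type nitrogen, simply joined differently, the change to 1-carboxyethyl gives an 8200-fold lower number from compound 2 to compound 3 (3.91 log units; beyond the scatter) in a large step. The comparison with the alcohol separates what the earlier pair had mixed, since carboxy in place of hydroxymethyl on the same saturated chain carbon gives a 3.8-fold higher number from compound 1 to compound 3 (0.58 log units; beyond the scatter) in a step that is modest, although beyond the scatter. Across these three compounds, the large rise therefore goes with the unbranched 2-carboxyethyl group and not with the presence of a carboxylic acid as such, and nothing available here explains this dependence on arrangement.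

The compounds shown leave open whether the opposite configuration at the defined stereocentre of 1-carboxyethyl would keep this low number, and whether an unbranched 2-hydroxyethyl group would rise as 2-carboxyethyl does. They also leave open how a methyl ester or an amine on that same carbon would compare with compound 1 and compound 3.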